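The compounds below may be only part of what the source reports. "The series", "measured", "known", "first", "only" and "open" are said of these compounds alone.

Compound 1 `C=C/C=C\[C@H](C)[C@H](OC(N)=O)[C@@H](C)[C@H](O)[C@@H](C)C/C(C)=C\[C@H](C)[C@@H](O)[C@@H](C)/C=C\CCc1cccc(F)c1` and compound 2 `C=C/C=C\[C@H](C)[C@H](OC(N)=O)[C@@H](C)[C@H](O)[C@@H](C)C/C(C)=C\[C@H](C)[C@@H](O)[C@@H](C)/C=C\CCc1cc(F)cc(F)c1` share one core and differ only where a 1.1-fold lower number from compound 1 to compound 2 (0.05 log units; within the scatter) tells it. In a functional assay on SK-OV-3 cells (Homo sapiens) for cytotoxicity (a higher number here means a weaker inhibitor, a lower number a stronger inhibitor), compound 1 gives 400 nM, and compound 2 gives 360 nM; these two numbers lie within the scatter of each other, so neither stands apart. Compound 3 `C=C/C=C\[C@H](C)[C@H](OC(N)=O)[C@@H](C)[C@H](O)[C@@H](C)C/C(C)=C\[C@H](C)[C@@H](O)[C@@H](C)/C=C\CCc1cc(O)cc(O)c1` carries 3,5-dihydroxyphenyl in place of 3,5-difluorophenyl on a saturated chain carbon, two bonds along the chain from a double-bonded chain carbon. Within the data shown here, no measured step exchanges fluorine for hydroxyl on the ring, so the only nearby step, a fluorine entering in place of hydrogen, offers no guide here. The change from compound 2 to compound 3 is therefore expected to give a 1.9-fold higher number from compound 2 to compound 3 (0.29 log units; within the scatter), and compound 3 is estimated at 700 nM, between 200 nM and 2500 nM.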

Compound 3, half-maximal inhibitory concentration: 40 nM
The estimate for compound 3 lay 18-fold (1.24 log units) above the measured number; the whole stated range lies above it.
By their numbers in this assay, from the lowest: compound 3; then compounds 2 and 1 (each within the scatter of the next).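

In this assay, the step of a 9.0-fold lower number from compound 2 to compound 3 (0.95 log units; beyond the scatter) shows that this position does respond to what the ring carries, for the 3,5-dihydroxyphenyl group gives a stronger inhibitor than the 3,5-difluorophenyl group, while the earlier fluorine step stayed within the scatter. The step of a 10-fold lower number from compound 1 to compound 3 (1.00 log units; beyond the scatter) points the same way, against the 3-fluorophenyl ring. Nothing available explains this gain. Still open, going by these compounds, is whether one hydroxyl on the ring would serve as well as two, and whether a methoxy group or an amine in its place would keep the gain.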